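Methoxyphenyl Ether Variation in a Fatty Acid Receptor Series

The source may report more compounds than this note shows. Statements on the series, on what has been measured and on what is new or still open speak of the compounds shown alone.

In a functional assay on cells for agonist activity at Free fatty acid receptor 1 (Mus musculus), read by FLIPR and calcium flux, with a stated time of 100 s (on this read-out lower numbers stand for an effect already at smaller amounts and higher numbers for an effect only at larger amounts of compound), compound 2 `O=C(O)C[C@@H]1CCCN1c1ccc(Oc2ccccc2F)cc1` gives 6900 nM, the higher of the two numbers measured in this assay. Compound 3 `O=C(O)C[C@@H]1CCCN1c1ccc(Oc2ccccc2-c2ccccc2)cc1` gives 1300 nM in this assay. Compound 1 `O=C(O)C[C@@H]1CCCN1c1ccc(Oc2ccccc2)cc1` gives > 16000 nM in this assay, and that value is a limit (the limit of > 16000 nM in this assay, at which 1 of the 3 values shown sits). Compound 4 `COc1ccc(Oc2ccc(N3CCC[C@H]3CC(=O)O)cc2)cc1` differs from compound 2 by 4-methoxyphenyl in place of 2-fluorophenyl on an oxygen on an aromatic ring. The measured steps on the same ring, an at least 2.3-fold lower number from compound 1 to compound 2 (0.36 log units; beyond the scatter) and a 5.3-fold lower number from compound 2 to compound 3 (0.72 log units; beyond the scatter), both lowered the number, as did an at least 12-fold lower number from compound 1 to compound 3 (1.09 log units; beyond the scatter). None of them places a methoxy group on that ring, so the step from compound 2 to compound 4 is expected to be small and of uncertain direction, a 1.4-fold lower number from compound 2 to compound 4 (0.14 log units; within the scatter). Compound 4 is therefore estimated at 5000 nM, with a range from 1500 nM to 16000 nM.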

Compound 4, half-maximal effective concentration: > 33000 nM
Compound 4: a limit, no number (the forecaster's own chance of this, stated with the estimate: 20%); middle value at least 6.6-fold (0.81 log units) from the limit.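

In this assay compound 4 stands at a limit of the assay and not at a number: the limit of > 33000 nM in this assay, at which 1 of the 4 values shown sits. Among these compounds, replacing 2-fluorophenyl with 4-methoxyphenyl on the oxygen on an aromatic ring is the only readable step that raises the number (an at least 4.7-fold higher number from compound 2 to compound 4 (0.67 log units; beyond the scatter)), so this position does not gain from every added group. The step from compound 1 to compound 4 cannot be read, as both values are limits.

On these data alone, what remains open is whether the methoxy group itself or its place on the ring sets this result. The compounds shown also do not tell how a chloro group, an ethoxy group or an amine on that ring would read.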